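The source may hold more compounds than are shown below. What is called first, only, known or untested is meant among the compounds shown, and "the series" means these compounds.

Working notes on the quinone amino-acid series in a functional assay on HeLa cells (Homo sapiens) for cytotoxicity, read by MTT assay, with a stated time of 72 h; on this read-out higher numbers stand for weaker inhibition and lower numbers for stronger inhibition.

Three members have been measured. Compound 1 `CC(C)(C)C1=CC(=O)C=C(NCC(=O)O)C1=O` carries the unsubstituted glycine chain and gives 132000 nM in this assay. Compound 2 `C[C@H](NC1=CC(=O)C=C(C(C)(C)C)C1=O)C(=O)O` gives 89100 nM and compound 3 `CSCC[C@H](NC1=CC(=O)C=C(C(C)(C)C)C1=O)C(=O)O` gives 77400 nM. Compound 2 thus stands second highest of the three numbers, with compound 3 nearest and compound 1 furthest, and every gap between these three values is within the scatter.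

The step of interest runs from compound 2 to compound 4 `CC(C)(C)C1=CC(=O)C=C(NCCC(=O)O)C1=O`, which has not been measured in this assay. The two share the same atoms joined differently: 2-carboxyethyl in place of 1-carboxyethyl on an amine nitrogen. Cut one bond further out, this reads as (1-carboxyethyl)amino to (2-carboxyethyl)amino, and the defined stereocentre of compound 2 is lost.

Going by the values given here, no measured step matches this rearrangement. The steps that touch the same saturated chain carbon are a 1.5-fold lower number from compound 1 to compound 2 (0.17 log units; within the scatter), a 1.7-fold lower number from compound 1 to compound 3 (0.23 log units; within the scatter) and a 1.2-fold lower number from compound 2 to compound 3 (0.06 log units; within the scatter), all within the scatter. Among the compounds with values here, the series so far is flat on this read-out, so no step beyond the scatter is expected here either; compound 4 is estimated at 100000 nM, range 45000 nM to 220000 nM, which corresponds to an expected step of a 1.1-fold higher number from compound 2 to compound 4 (0.05 log units; within the scatter).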

Compound 4, half-maximal inhibitory concentration: 47100 nM
Estimate against measurement, compound 4: 2.1-fold (0.33 log units) above; the range from low to high includes it.
By their numbers in this assay, from the lowest: compounds 4, 3, 2 and 1 (each within the scatter of the next, the first and the last beyond it).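

On the amine nitrogen, 2-carboxyethyl in place of 1-carboxyethyl gives a 1.9-fold lower number from compound 2 to compound 4 (0.28 log units; within the scatter) in this assay, so this rearrangement, which also removes the defined stereocentre of compound 2, does not separate the two compounds. The new information lies in the other step, carboxymethyl in place of carboxy on the saturated chain carbon bound to the amine nitrogen: a 2.8-fold lower number from compound 1 to compound 4 (0.45 log units; beyond the scatter) is the first step in the series beyond the scatter, though it remains modest and every other step shown stays within the scatter. No evidence bearing on the origin of this step is available.

Going by these compounds, whether a longer chain on the same amine nitrogen, such as 3-carboxypropyl, would extend the step seen from the glycine chain of compound 1 remains open, as does the effect of the opposite configuration at the stereocentre of compound 2. All the compounds shown carry a free carboxylic acid, so the outcome of replacing it with a primary amide, a methyl ester or a tetrazole on the same chain also remains open.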